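Aryl change on the aromatic nitrogen: outlook for compound 4

The source may report more compounds than this note shows. Statements on the series, on what has been measured and on what is new or still open speak of the compounds shown alone.

In a functional assay on A549 cells (Homo sapiens) for cytotoxicity, read by MTT assay, with a stated time of 72 h (on this read-out lower numbers stand for stronger inhibition and higher numbers for weaker inhibition), compound 3 `Cc1cc(=O)n(-c2ccccc2OC(F)(F)F)nc1C(=O)Nc1ccc(Oc2ncnc3[nH]ccc23)cc1` gives 16200 nM, the lowest of the two numbers in hand; compound 2 `Cc1cc(=O)n(-c2cccc(F)c2)nc1C(=O)Nc1ccc(Oc2ncnc3[nH]ccc23)cc1` gives 34800 nM. Compound 1 `Cc1cc(=O)n(-c2ccc(F)cc2)nc1C(=O)Nc1ccc(Oc2ncnc3[nH]ccc23)cc1` reaches only an assay limit, > 60000 nM, recorded as the limit of > 60000 nM in this assay, at which 1 of the 3 values shown sits. Of the measured steps, a 2.1-fold lower number from compound 2 to compound 3 (0.33 log units; beyond the scatter) and an at least 3.7-fold lower number from compound 1 to compound 3 (0.56 log units; beyond the scatter), whereas an at least 1.7-fold lower number from compound 1 to compound 2 (0.23 log units; that floor lies within the scatter). Compound 4 `Cc1cc(=O)n(-c2ccc(Br)cc2F)nc1C(=O)Nc1ccc(Oc2ncnc3[nH]ccc23)cc1` differs from compound 3 by 4-bromo-2-fluorophenyl in place of 2-(trifluoromethoxy)phenyl on an aromatic nitrogen. All three measured steps change the aryl on the same aromatic nitrogen, and the two that lowered the number both led to compound 3; compound 4 keeps a fluorine within its 4-bromo-2-fluorophenyl group. The expected step in this assay is a 1.2-fold higher number from compound 3 to compound 4 (0.09 log units; within the scatter), within the scatter. Compound 4 is estimated at 20000 nM, with a range from 7000 nM to 60000 nM.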

Compound 4, half-maximal inhibitory concentration: 3770 nM
Compound 4: middle estimate off by 5.3-fold (0.72 log units), on the high side; measured number below the stated range.
By their numbers in this assay, from the lowest: compound 4; then compound 3; then compound 2. At a limit, above all of these: compound 1.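

Changing the aryl on this aromatic nitrogen moves the number further than any earlier change in this assay: a 4.3-fold lower number from compound 3 to compound 4 (0.63 log units; beyond the scatter), a 9.2-fold lower number from compound 2 to compound 4 (0.97 log units; beyond the scatter), and an at least 15-fold lower number from compound 1 to compound 4 (1.20 log units; beyond the scatter). Compound 4, with 4-bromo-2-fluorophenyl, therefore has the lowest number in the series, and its steps to all other compounds lie beyond the scatter. Compound 1 is an assay limit, so its step is only a floor: the limit of > 60000 nM in this assay, at which 1 of the 4 values shown sits.

The compounds shown do not separate the contribution of the bromine from that of the fluorine in 4-bromo-2-fluorophenyl. As far as these compounds go, how an aryl carrying an amine or a carboxylic acid would read at this position also stays open.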